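Swapping Nitro for Chloro in a Weakly Active Series

The compounds below may be only part of what the source reports. "The series", "measured", "known", "first", "only" and "open" are said of these compounds alone.

Compound 1 `O=C(CSc1nc2ccc(NC(=O)c3ccc([N+](=O)[O-])cc3)cc2s1)NCc1ccccc1` carries a 4-nitrophenyl group on a carbonyl carbon. In a functional assay on MCF7 cells (Homo sapiens) for cytotoxicity, read by MTT assay, with a stated time of 48 h (on this read-out higher numbers stand for weaker inhibition and lower numbers for stronger inhibition), compound 1 gives only a limit, > 100000 nM, so its true potency is not pinned down. Two related compounds give numbers. Compound 3 `CC(=O)Nc1ccc2nc(SCC(=O)NCc3ccccc3)sc2c1`, with a methyl in place of the 4-nitrophenyl on that carbonyl carbon, gives 17600 nM in this assay, and an at least 5.6-fold lower number from compound 1 to compound 3 (0.75 log units; beyond the scatter). Compound 2 `COc1ccc(CNC(=O)CSc2nc3ccc(NC(=O)c4ccccc4OC)cc3s2)cc1`, which carries methoxy groups at two places, gives 9300 nM in this assay.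

Compound 4 `O=C(CSc1nc2ccc(NC(=O)c3ccc(Cl)cc3)cc2s1)NCc1ccccc1` differs from compound 1 in one place: chloro in place of nitro on an aromatic carbon. Among the measured compounds shown here, no measured step swaps nitro for chloro, so the step from compound 1 to compound 3 is the only guide, and the limit of > 100000 nM in this assay, at which 1 of the 3 values shown sits, leaves the starting point open. Compound 4 keeps the aromatic ring that compound 3 loses, so a step in this assay no larger than that one is expected, toward lower numbers if any. Compound 4 is expected to give 50000 nM in this assay, between 12000 nM and 200000 nM, with a fair chance that only a limit is returned. The expected step is an at least 2.0-fold lower number from compound 1 to compound 4 (0.30 log units; that floor lies within the scatter).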

Compound 4, half-maximal inhibitory concentration: 25900 nM
Compound 4: middle estimate off by 1.9-fold (0.29 log units), on the high side; the measured number falls inside the stated range.
By their numbers in this assay, from the lowest: compounds 2, 3 and 4 (each within the scatter of the next, the first and the last beyond it). At a limit, above all of these: compound 1.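

Replacing nitro with chloro on this aromatic carbon, para to a large group, turns a limit into a measured number in this assay, with an at least 3.8-fold lower number from compound 1 to compound 4 (0.58 log units; beyond the scatter). Putting 4-chlorophenyl in place of methyl on the carbonyl carbon gives a 1.5-fold higher number from compound 3 to compound 4 (0.17 log units; within the scatter), so this pair shows that keeping an aromatic ring on that carbonyl carbon does not by itself hold the number at the level of compound 1, and the group on the ring matters here. The true size of the change from nitro to chloro remains unknown because compound 1 is recorded only as a limit: the limit of > 100000 nM in this assay, at which 1 of the 4 values shown sits.

As far as these compounds go, whether an amine or a carboxylic acid on this same aromatic carbon would give a number close to that of compound 4, or would return only a limit, remains open. From the compounds shown here alone, compound 2 differs from the others in more than one place, so its steps cannot be read, and whether chloro would have a similar effect with a different group on the other end of the molecule also remains open.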